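Biphenyl replaces tert-butyl in a bis(trifluoromethyl)benzenesulfonamide series

The compounds below may be only part of what the source reports. "The series", "measured", "known", "first", "only" and "open" are said of these compounds alone.

Measured so far in a functional assay on A2780 cells (Homo sapiens) for inhibition, read by MTT assay, with a stated time of 72 h; on this read-out lower numbers stand for stronger inhibition of growth and higher numbers for weaker inhibition of growth:
Compound 1 `O=S(=O)(NCCCNCc1cccc2ccccc12)c1cc(C(F)(F)F)cc(C(F)(F)F)c1`: 3100 nM
Compound 2 `CC(C)(C)c1ccc(CNCCNS(=O)(=O)c2cc(C(F)(F)F)cc(C(F)(F)F)c2)cc1`: 14000 nM
Compound 3 `O=S(=O)(NCCCNCc1ccc(Cl)cc1)c1cc(C(F)(F)F)cc(C(F)(F)F)c1`: 1800 nM

Compound 2 gives the highest number of the three: compound 1 lies a good distance below it, and compound 3 lies further below still, both gaps beyond the scatter. Within the data shown here, the one step among the measured compounds, a 1.7-fold lower number from compound 1 to compound 3 (0.24 log units; within the scatter), swaps the aromatic group on the saturated chain carbon bound to the amine nitrogen and stays within the scatter.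

Compound 4 `O=S(=O)(NCCNCc1ccc(-c2ccccc2)cc1)c1cc(C(F)(F)F)cc(C(F)(F)F)c1` differs from compound 2 by phenyl in place of tert-butyl on an aromatic carbon. Among the measured compounds shown here, no measured pair shows this kind of change; the step from compound 1 to compound 3 concerns a different part of the molecule and is the only guide to how much the terminal aromatic portion matters, and there it moved little. The shared core of compounds 2 and 4, with the shorter linker, is otherwise measured only once.

Compound 4 is therefore expected to give a number close to that of compound 2, with a 1.8-fold lower number from compound 2 to compound 4 (0.24 log units; within the scatter) as the estimated step, and a wide range. Compound 4 is estimated at 8000 nM, between 2500 nM and 25000 nM.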

Compound 4, concentration for 50% growth inhibition: 2600 nM
Estimate against measurement, compound 4: 3.1-fold (0.49 log units) above, within the range that was stated.
By their numbers in this assay, from the lowest: compounds 3, 4 and 1 (each within the scatter of the next); then compound 2.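

In this assay, the step of a 5.4-fold lower number from compound 2 to compound 4 (0.73 log units; beyond the scatter) is the first change at the terminal aromatic portion, among the compounds shown, to lie beyond the scatter. Placing phenyl instead of tert-butyl on this aromatic carbon, para to a large group, therefore changes the number measurably on the shared core of compound 2 and compound 4, whereas the only earlier step, a 1.7-fold lower number from compound 1 to compound 3 (0.24 log units; within the scatter), stayed within the scatter and gave no sign of a change this large. Nothing measured here accounts for the lower number seen with phenyl.

The compounds shown leave open whether the same swap would also lower the number on the longer chain carried by compound 1 and compound 3. They also leave open whether the aromatic ring of phenyl is what counts at this carbon, a question that a cyclohexyl group or a pyridyl ring in the same place would address.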